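The source may hold more compounds than are shown below. What is called first, only, known or untested is meant among the compounds shown, and "the series" means these compounds.

Measured compounds in an assay on CHO cells for displacement of a labelled ligand from prostaglandin D2 receptor 2 (Homo sapiens); a higher number here means a weaker inhibitor, a lower number a stronger inhibitor:
- compound 1 `O=C(O)COc1ccc(F)cc1C1CCCCC1`, 446 nM
- compound 2 `O=C(O)COc1ccc(-c2ccc(F)cc2)cc1C1CCCCC1`, 99 nM

Compound 2 stands lowest of the two numbers shown in this assay; its nearest neighbour is compound 1, and the step of a 4.5-fold lower number from compound 1 to compound 2 (0.65 log units; beyond the scatter) tells how far apart they lie. Compound 3 `O=C(O)COc1ccc(Br)cc1C1CCCCC1` has not yet been measured. It differs from compound 2 in one place: bromo in place of 4-fluorophenyl on an aromatic carbon. Among the compounds with values here, the one measured step that bears on this is the one from compound 1 to compound 2, where a 4-fluorophenyl group took the place of fluoro on an aromatic carbon and the number fell, as a 4.5-fold lower number from compound 1 to compound 2 (0.65 log units; beyond the scatter) shows. Compound 3 goes the other way: the 4-fluorophenyl group leaves and a single halogen atom, bromo, enters. Because compound 1 gives 446 nM with fluoro in that place, compound 3 is expected to land nearer to compound 1 than to compound 2, so a rise in the number is expected, of about a 3.0-fold higher number from compound 2 to compound 3 (0.48 log units; beyond the scatter). The estimate for compound 3 in this assay is 300 nM, with a range from 120 nM to 800 nM.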

Compound 3, inhibition constant: 83 nM
Beside the measured number, compound 3's estimate is 3.6-fold (0.56 log units) above it; the whole stated range lies above it.
By their numbers in this assay, from the lowest: compounds 3 and 2 (each within the scatter of the next); then compound 1.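

In this assay the place para to the carboxymethoxy group and meta to the cyclohexyl group turns out not to need the 4-fluorophenyl group: a single bromo atom does the same job, with a 1.2-fold lower number from compound 2 to compound 3 (0.08 log units; within the scatter) as the step. Compound 2 alone suggested that the gain over fluoro came with the added ring, but the halogen swap gives a 5.4-fold lower number from compound 1 to compound 3 (0.73 log units; beyond the scatter) as its step, a change of similar size with no ring added, so heavy atom count does not order these three compounds: fluoro stands apart, while bromo and 4-fluorophenyl, one atom against seven, cannot be told apart. No measurement at hand explains why fluoro differs from the other two groups.

The compounds shown leave open whether chloro or iodo would fall with bromo or with fluoro, and whether a non-halogen group such as methyl or an amine would hold the number at this place. They also leave open whether bromo and 4-fluorophenyl would stay level if a shorter chain such as ethyl took the place of the cyclohexyl group.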